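This account rests on a few compounds, and the source may have more. Where it says the series, first, only, none or still open, it means among the compounds named here.

Measured compounds:
compound 1 `COc1cc(-c2cc(CO[C@@H]3O[C@H](CSc4ncn[nH]4)[C@H]4OC5(CCCC5)O[C@@H]34)on2)cc(OC)c1OC`: 94000 nM
compound 2 `COc1cc(-c2nc(CO[C@@H]3O[C@H](CSc4ncn[nH]4)[C@H]4OC5(CCCC5)O[C@@H]34)no2)cc(OC)c1OC`: 44000 nM
compound 3 `O=[N+]([O-])c1ccc(-c2nc(CO[C@@H]3O[C@H](CO)[C@H]4OC5(CCCC5)O[C@@H]34)no2)cc1`: 50000 nM

In a functional assay on T47D cells (Homo sapiens) for antiproliferative activity, read by sulforhodamine B assay, with a stated time of 48 h (on this read-out lower numbers stand for stronger inhibition of growth and higher numbers for weaker inhibition of growth), compound 2 gives the lowest of the three numbers, but compound 3 sits within the usual scatter of it, so the two cannot be told apart; only compound 1 lies beyond the scatter, with the weaker value. Compound 4 `O=[N+]([O-])c1ccc(-c2nc(CO[C@@H]3O[C@H](CSc4ncn[nH]4)[C@H]4OC5(CCCC5)O[C@@H]34)no2)cc1` is not yet measured. It differs from compound 2 in one place: 4-nitrophenyl in place of 3,4,5-trimethoxyphenyl on an aromatic carbon. Among the measured compounds shown here, no measured pair shows this exchange on its own, so its size is unknown here. Compound 3 carries the same 4-nitrophenyl group together with a different side chain and gives a number close to that of compound 2. Compound 4 is therefore expected to show a step of a 1.1-fold higher number from compound 2 to compound 4 (0.06 log units; within the scatter), none beyond the scatter. The estimate for compound 4 is 50000 nM, within 20000 nM to 120000 nM.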

Compound 4, concentration for 50% growth inhibition: 20000 nM
Estimate against measurement, compound 4: 2.5-fold (0.40 log units) above, within the range that was stated.
By their numbers in this assay, from the lowest: compound 4; then compounds 2, 3 and 1 (each within the scatter of the next, the first and the last beyond it).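

In this assay, among the compounds shown here, 4-nitrophenyl in place of 3,4,5-trimethoxyphenyl gives a 2.2-fold lower number from compound 2 to compound 4 (0.34 log units; beyond the scatter) and so shows, as the earlier compounds could not, that the group at this position changes the result. With 4-nitrophenyl kept, (1H-1,2,4-triazol-5-yl)sulfanyl in place of hydroxy gives a 2.5-fold lower number from compound 3 to compound 4 (0.40 log units; beyond the scatter) and so shows that the side chain matters too. No measurement given here explains either step.

As far as these compounds go, whether an amine or a carboxylic acid on the phenyl ring would lower the number further remains open. From the compounds shown here alone, it is also open whether the 4-nitrophenyl exchange would act the same way on the five-membered ring of compound 1.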